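Shifting One Hydroxyl Group on a Weak Inhibitor

A few compounds are considered here, and "the series" means these few. Any claim that something is new, unique, unknown or untested is made for them only; others in the source may bear on it.

Among the measured compounds shown here, compound 1 `O=C(/C=C/c1cccc(O)c1)CC(=O)/C=C/c1cccc(O)c1O` and compound 2 `O=C(/C=C/c1ccccc1O)/C=C/c1cccc(O)c1O` are the only two compounds measured so far. In a functional assay, with a stated time of 30 min (a higher number here means a weaker inhibitor, a lower number a stronger inhibitor), compound 2 gives 99000 nM and holds the higher of the two numbers, which makes it the weaker inhibitor of the pair. Compound 1 gives 29000 nM and that gap lies beyond the usual scatter of repeated measurements.

The next structure is compound 3 `O=C(/C=C/c1ccc(O)cc1)/C=C/c1cccc(O)c1O` with the same atoms as compound 2 joined differently. The change puts 4-hydroxyphenyl in place of 2-hydroxyphenyl on a double-bonded chain carbon bound to a double-bonded chain carbon and alters nothing else.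

For the measured compounds named here, no measured pair here shows what such a shift does, so the data offer no direct guide. The starting point is compound 2 at 99000 nM and the expectation is no step beyond the scatter, with a slight lean towards a lower number. The estimated step is a 1.4-fold lower number from compound 2 to compound 3 (0.15 log units; within the scatter) and it is expected to be small. In this assay compound 3 is expected to read 70000 nM with an estimated range from 25000 nM to 160000 nM once it is tested.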

Compound 3, half-maximal inhibitory concentration in the functional assay: 40000 nM
Compound 3: the middle estimate sits 1.8-fold (0.24 log units) above what was measured; measured number inside the range.
By their numbers in the functional assay, from the lowest: compounds 1 and 3 (each within the scatter of the next); then compound 2.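

Among the compounds shown here, until now no two measured compounds differed in one place only, so nothing showed whether the arrangement of this ring's hydroxyl group matters, and in the functional assay compound 3 now gives 40000 nM. Putting 4-hydroxyphenyl in place of 2-hydroxyphenyl on a double-bonded chain carbon bound to a double-bonded chain carbon leaves the atoms the same, yet in the functional assay it gives a 2.5-fold lower number from compound 2 to compound 3 (0.39 log units; beyond the scatter) and this modest step shows that how the atoms are joined at this place can alter the reading on its own. In a physicochemical assay for solubility, using the shake flask method, with a stated time of 12 h (on this read-out lower numbers stand for lower solubility and higher numbers for higher solubility), the same change gives a 1.3-fold lower number from compound 2 to compound 3 (0.10 log units; within the scatter) with compound 2 at 151000 nM and compound 3 at 120000 nM and so the two compounds cannot be told apart on that read-out, which means the step in inhibition comes with no solubility difference that can be read.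

No measurement shown here bears on why the inhibition step occurs. As far as these compounds go, it also remains open whether a methoxy group, an amine or a carboxylic acid in place of the hydroxyl on 4-hydroxyphenyl would keep, extend or lose this step.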